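Same atoms, joined differently: a pyrazole swap

The source may report more compounds than this note shows. Statements on the series, on what has been measured and on what is new or still open speak of the compounds shown alone.

Measured in a functional assay on SW-620 cells (Homo sapiens) for inhibition, read by MTT assay, with a stated time of 72 h; a lower number here means a stronger inhibitor of growth, a higher number a weaker inhibitor of growth:
- compound 1 `Cc1cc(CN2CCN(c3c(Cl)cnc4[nH]c(-c5cnn(C)c5)nc34)CC2)no1` gives 1800 nM
- compound 2 `Cc1cc(CN2CCN(c3c(Cl)cnc4[nH]c(-c5ccc(N6CCN[C@@H](C)C6)cc5)nc34)CC2)no1` gives 160 nM

Compound 1 has the higher number of the two, which makes it the weaker inhibitor of growth, and the gap to compound 2 lies beyond the usual scatter. Compound 3 `Cc1cc(CN2CCN(c3c(Cl)cnc4[nH]c(-c5ccn(C)n5)nc34)CC2)no1` has 1-methyl-1H-pyrazol-3-yl in place of the 1-methyl-1H-pyrazol-4-yl of compound 1 on an aromatic carbon (1-methyl-1H-pyrazol-3-yl in place of 1-methyl-1H-pyrazol-4-yl on an aromatic carbon). Among the measured compounds shown here, no measured pair shows what this swap does, so no change beyond the scatter is expected in this assay. The estimated step is small, a 1.1-fold higher number from compound 1 to compound 3 (0.05 log units; within the scatter). For compound 3 the expected value is 2000 nM, with an estimated range from 800 nM to 5000 nM.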

Compound 3, concentration for 50% growth inhibition: 2600 nM
Estimate against measurement, compound 3: 1.3-fold (0.11 log units) below; low and high end bracket the measured number.
By their numbers in this assay, from the lowest: compound 2; then compounds 1 and 3 (each within the scatter of the next).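

Replacing 1-methyl-1H-pyrazol-4-yl with 1-methyl-1H-pyrazol-3-yl gives a 1.4-fold higher number from compound 1 to compound 3 (0.16 log units; within the scatter) in this assay, so this assay does not separate these two ways of joining the pyrazole to the shared core. Among the compounds shown here, this is the only direct comparison of the two groups here, and it shows that the swap leaves the number within the scatter for this one pair. Nothing available explains this result.

Still open, going by these compounds, is whether the same holds when the rest of the molecule changes. It is also unknown what a pyridine ring, or a pyrazole carrying an amine on a longer chain in place of the methyl, would do at this position.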